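A few compounds are considered here, and "the series" means these few. Any claim that something is new, unique, unknown or untested is made for them only; others in the source may bear on it.

Of the compounds shown here, three of the shared core have been measured: compound 1 `CCCCc1ccc(S(=O)(=O)N2CCN(C(=O)Oc3ccc([N+](=O)[O-])cc3)CC2)cc1`, compound 2 `O=C(Oc1ccc([N+](=O)[O-])cc1)N1CCN(S(=O)(=O)c2ccc(Oc3cccc(Cl)c3)cc2)CC1` and compound 3 `O=C(Oc1ccc([N+](=O)[O-])cc1)N1CCN(S(=O)(=O)c2ccc(Oc3ccc(Cl)cc3)cc2)CC1`. In an assay on isolated protein for inhibition of Fatty-acid amide hydrolase 1 (Homo sapiens), read by fluorescence (on this read-out lower numbers stand for stronger inhibition and higher numbers for weaker inhibition), compound 1 gives 179 nM, compound 2 gives 380 nM and compound 3 gives 153 nM. Compound 3 therefore has the lowest number of the three, though one of its gaps a 1.2-fold lower number from compound 1 to compound 3 (0.07 log units; within the scatter) is within the scatter, while the other 2.5-fold lower number from compound 2 to compound 3 (0.40 log units; beyond the scatter) is beyond it.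

Compound 4 `O=C(Oc1ccc([N+](=O)[O-])cc1)N1CCN(S(=O)(=O)c2ccc(Oc3ccccc3Cl)cc2)CC1` is still to be measured in this assay. The change from compound 3 is 2-chlorophenyl in place of 4-chlorophenyl on an oxygen on an aromatic ring. Among the measured compounds shown here, the only step that bears on it is the one from compound 2 to compound 3 a 2.5-fold lower number from compound 2 to compound 3 (0.40 log units; beyond the scatter), where relocating the chlorine on the phenoxy ring produced a modest shift; the step from compound 1 to compound 2 a 2.1-fold higher number from compound 1 to compound 2 (0.33 log units; beyond the scatter) shows the same magnitude in the other sense. For the measured compounds named here, no ortho-substituted phenoxy analogue has been measured, so the direction for compound 4 rests on this alone, and a modest rise in the number is expected, a 2.0-fold higher number from compound 3 to compound 4 (0.29 log units; within the scatter). Compound 4 is estimated at 300 nM, within 100 nM to 900 nM.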

Compound 4, half-maximal inhibitory concentration: 1150 nM
Estimate against measurement, compound 4: 3.8-fold (0.58 log units) below, outside the stated range (above it).
By their numbers in this assay, from the lowest: compounds 3 and 1 (each within the scatter of the next); then compound 2; then compound 4.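

In this assay, the chlorine's location on the phenoxy ring matters more than compounds 2 and 3 alone suggested: 2-chlorophenyl is the poorest of the three isomers, giving a 7.5-fold higher number from compound 3 to compound 4 (0.88 log units; beyond the scatter) and a 3.0-fold higher number from compound 2 to compound 4 (0.48 log units; beyond the scatter), so the numbers in this set rise in the order compound 3, compound 2, compound 4. Against butyl, only 2-chlorophenoxy carries a large penalty, at a 6.4-fold higher number from compound 1 to compound 4 (0.81 log units; beyond the scatter), whereas 4-chlorophenoxy stays level with butyl at a 1.2-fold lower number from compound 1 to compound 3 (0.07 log units; within the scatter). No supporting data are available to explain this rise.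

As far as these compounds go, whether the loss follows chlorine specifically or any group at this place remains open, and 2-fluorophenoxy, 2-methoxyphenoxy or unsubstituted phenoxy would separate these cases. Also open, from the compounds shown here alone, is whether the same order among the isomers would hold with a bromine or methyl group in place of chlorine.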